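Nitrophenyl Hydrazone Against a Limit-Bound Starting Point

The source may report more compounds than this note shows. Statements on the series, on what has been measured and on what is new or still open speak of the compounds shown alone.

Compound 3 `COc1ccc(/C=N/Nc2ncc3c(n2)n(C2CCCC2)c(=O)c(=O)n3C)c(OC)c1` sits at a limit in a functional assay on HCT-116 cells (Homo sapiens) for antiproliferative activity, read by MTT assay; on this read-out lower numbers stand for stronger inhibition and higher numbers for weaker inhibition: in this assay compound 3 gives > 100000 nM, a limit of the assay and not a number. Compound 1 `Cc1cccc(/C=N/Nc2ncc3c(n2)n(C2CCCC2)c(=O)c(=O)n3C)c1` also gives > 100000 nM, again a limit, which matches (the limit of > 100000 nM in this assay, at which 2 of the 3 values shown sit). Only compound 2 `Cc1cc(C)c(/C=N/Nc2ncc3c(n2)n(C2CCCC2)c(=O)c(=O)n3C)c(C)c1` gives a number in this assay, 7920 nM. Compound 4 `Cn1c(=O)c(=O)n(C2CCCC2)c2nc(N/N=C/c3cccc([N+](=O)[O-])c3)ncc21` differs from compound 3 by 3-nitrophenyl in place of 2,4-dimethoxyphenyl on a carbon with a double bond to nitrogen. The measured steps that bear on this are an at least 12-fold higher number from compound 2 to compound 3 (1.10 log units; beyond the scatter) and a step that the two limits leave unreadable from compound 1 to compound 3. Going by the values given here, because a step that the two limits leave unreadable from compound 1 to compound 3 shows nothing readable and an at least 12-fold higher number from compound 2 to compound 3 (1.10 log units; beyond the scatter) is the only readable step, compound 4 is expected to stay near the limit, with an at least 1.2-fold lower number from compound 3 to compound 4 (0.09 log units; that floor lies within the scatter). For compound 4 the estimate is 80000 nM, between 20000 nM and 300000 nM.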

Compound 4, half-maximal inhibitory concentration: 15200 nM
Beside the measured number, compound 4's estimate is 5.3-fold (0.72 log units) above it, and the stated range ends above it.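

In this assay, 3-nitrophenyl on a carbon with a double bond to nitrogen gives an at least 6.5-fold lower number from compound 3 to compound 4 (0.81 log units; beyond the scatter). Set against the methyl group, the nitro group on an aromatic carbon gives an at least 6.5-fold lower number from compound 1 to compound 4 (0.81 log units; beyond the scatter), so a single change to the aromatic ring can move a compound off the limit. Going by these compounds alone, the 2,4,6-trimethylphenyl group is thus not the only group here that gives a number, and its replacement gives a 1.9-fold higher number from compound 2 to compound 4 (0.28 log units; within the scatter).

The compounds shown leave open whether an amine or a carboxylic acid in place of the nitro group would keep a readable number. How far the compounds at the limit truly lie from the others also stays unknown: the limit of > 100000 nM in this assay, at which 2 of the 4 values shown sit.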